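This account rests on a few compounds, and the source may have more. Where it says the series, first, only, none or still open, it means among the compounds named here.

Measured so far:
compound 1 `Cc1cc(NCc2ncc[nH]2)n2nc(C)c(-c3ccccc3)c2n1` — < 5000 nM
compound 2 `Cc1cc(NCc2ccccn2)n2ncc(-c3ccc(F)c(Cl)c3)c2n1` — < 5000 nM

In a physicochemical assay for solubility, read by HPLC, using the shake flask method, measured as kinetic solubility, with a stated time of 2 h, at pH 7.4 (on this read-out lower numbers stand for lower solubility and higher numbers for higher solubility), compound 2 gives < 5000 nM, which is a limit of the assay and not a number. Compound 1, in this assay, likewise gives < 5000 nM, also a limit. Both values shown thus sit at the same limit, as the limit of < 5000 nM in this assay, at which 2 of the 2 values shown sit, records, so compound 2 cannot be placed above or below compound 1 on these numbers.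

Compound 3 `Cc1cc(NCc2ccccn2)n2ncc(-c3ccc(O)cc3)c2n1` has not yet been measured in this assay. Compared with compound 2, its change is 4-hydroxyphenyl in place of 3-chloro-4-fluorophenyl on an aromatic carbon. For the measured compounds named here, no step between measured compounds is available for this change, so the expectation rests on the structures alone. The step from compound 2 to compound 3 in this assay is expected to be a gain beyond the scatter, an at least 1.6-fold higher number from compound 2 to compound 3 (0.20 log units; that floor lies within the scatter). For compound 3 the estimated solubility in this assay is 8000 nM, with a range from 3000 nM to 30000 nM.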

Compound 3, solubility: 10900 nM
Compound 3: middle estimate off by 1.4-fold (0.13 log units), on the low side; the range from low to high includes it.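

In this assay, compounds 2 and 3 differ in one place only, and putting 4-hydroxyphenyl in place of 3-chloro-4-fluorophenyl there gives an at least 2.1-fold higher number from compound 2 to compound 3 (0.33 log units; beyond the scatter). For the compounds shown here, this shows that the read-out can respond to a change at this aromatic carbon of the five-membered aromatic ring, and compound 3 gives the only value shown that is a number and not a limit. The full size of the step stays unknown because compound 2 sits at a limit: the limit of < 5000 nM in this assay, at which 2 of the 3 values shown sit.

The compounds shown do not separate the arrival of the hydroxyl group from the departure of the chlorine and fluorine, so it remains open which of these matters. Nor do they show whether a methoxy group, an amine or a carboxylic acid on that phenyl ring would give a comparable step.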